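The compounds below may be only part of what the source reports. "The series", "measured", "known", "first", "only" and "open" are said of these compounds alone.

Compound 1, `CC1CC/C(=N\Nc2ccccc2)c2ncc(C(N)=O)c(=O)n21`: > 1000 umol/kg
Compound 2, `CC1CCC(=NNc2ccccc2)c2ncc(C(=O)O)c(=O)n21`: 1.2 umol/kg
Compound 3, `CC1CC/C(=N\Nc2cccc(Cl)c2)c2ncc(C(=O)O)c(=O)n21`: > 100 umol/kg

All three compounds were tested in a functional assay on the whole organism for inhibition, with Rattus norvegicus as the target; on this read-out lower numbers stand for an effect already at smaller amounts and higher numbers for an effect only at larger amounts of compound. Among the compounds with values here, compound 2 is the only one with a measured number, giving 1.2 umol/kg in this assay. Compound 1 reached only a limit of the assay, > 1000 umol/kg, which is the limit of > 1000 umol/kg in this assay, at which 1 of the 3 values shown sits. Compound 3 likewise reached only a limit, > 100 umol/kg, which is the limit of > 100 umol/kg in this assay, at which 1 of the 3 values shown sits. So compound 3 stands at a limit and not at a number, and no pair of measured compounds differs in a single place, so no measured step can be sized here.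

Compound 4, `CC1CC/C(=N\Nc2ccccc2O)c2ncc(C(=O)O)c(=O)n21`, is not yet measured. It differs from compound 3 by 2-hydroxyphenyl in place of 3-chlorophenyl on an amine nitrogen.

Compound 3 sits at a limit, and compound 2 carries a plain phenyl group with a number in this assay, so for compound 4 a move back toward an effect at smaller amounts is expected, roughly an at least 3.3-fold lower number from compound 3 to compound 4 (0.52 log units; beyond the scatter). The estimate for compound 4 in this assay is 30 umol/kg. Its expected range for compound 4 runs from 3 umol/kg to 300 umol/kg, with a real chance that the assay again reports only a limit.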

Compound 4, dose for 50% inhibition: > 100 umol/kg
Compound 4 ended at the assay's limit; the forecaster's own chance of this, stated with the estimate: 40%; middle value at least 3.3-fold (0.52 log units) from the limit.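

Compound 3 and compound 4 both ended at a limit and not at a number in this assay, so the step between them cannot be read: the limit of > 100 umol/kg in this assay, at which 2 of the 4 values shown sit.

The compounds shown leave open at what dose compound 3 and compound 4 would reach the effect, and whether the 3-chlorophenyl or the 2-hydroxyphenyl group gives the lower number.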